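A few compounds are considered here, and "the series" means these few. Any claim that something is new, unique, unknown or untested is made for them only; others in the source may bear on it.

Compound 1, `Cc1ccc2nc(-c3ccccc3N(C)C)[nH]c(=O)c2c1`, and compound 2, `Cc1ccc2nc(-c3ccccc3C)[nH]c(=O)c2c1`, share one core and differ only in the group that sits on the attached six-membered carbon ring. In an assay on isolated protein for inhibition of DNA topoisomerase 1 (Homo sapiens), with a stated time of 30 min, tested at 20 uM (on this read-out higher numbers stand for a stronger effect at the one concentration tested and lower numbers for a weaker effect), compound 1 gives 21.1%. In this assay compound 2 gives "not determined" (no result reported), so compound 2 stands without a number of its own; the only measured point in this small set is compound 1.

Compound 3, `Cc1ccc2nc(-c3ccccc3OC(F)(F)F)[nH]c(=O)c2c1`, is the next compound to be tested in this assay. Compared with compound 2 the change is trifluoromethoxy in place of methyl on an aromatic carbon. Among the measured compounds shown here, since compound 2 has no value, no step between two measured compounds can be drawn here, and the step from compound 2 to compound 3 in this assay cannot be sized in either direction. What remains as a guide is compound 1, whose reading in this assay is 21.1%, a modest effect at the single concentration tested.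

On that basis compound 3 is expected to give about 20% in this assay, with a likely range from 5% to 40%.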

Compound 3, a percentage reported as inhibition, at one concentration (the size of the read-out at that concentration, not a potency): 0%
The estimate for compound 3 lay 20 percentage points above the measured number; the whole stated range lies above it.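

In this assay, among the compounds shown here, the exchange of dimethylamino for trifluoromethoxy on the same aromatic carbon gives a number 21.1 percentage points lower from compound 1 to compound 3 (beyond the scatter), and this is the first step at this position that can be read at all. It shows that the group placed here matters to the read-out: with these two groups on an otherwise identical structure, the reading goes from a modest effect for compound 1 to no effect for compound 3 at the one concentration tested. Nothing shown here accounts for that difference, so the finding stands as an observation without an explanation.

The steps involving compound 2 cannot be read, since it has no number, which leaves it unknown how a plain methyl group at this position compares with either dimethylamino or trifluoromethoxy. Also open, as far as these compounds go, is whether the reading of compound 1 is specific to dimethylamino, a question that a simple amino group, a methoxy group or a longer dialkylamino chain at the same place could help to answer.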